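Swapping nitro for methyl on the triazole-linked phenyl ring

The compounds below may be only part of what the source reports. "The series", "measured", "known", "first", "only" and "open" are said of these compounds alone.

The series shares one core, carried in compound 1 `CCOC(=O)C1=Cc2ccccc2OC1(OCc1cn(CC(=O)Nc2ccccc2F)nn1)C(F)(F)F` and compound 2 `CCOC(=O)C1=Cc2ccccc2OC1(OCc1cn(-c2ccc([N+](=O)[O-])cc2)nn1)C(F)(F)F`. In a functional assay on MCF7 cells (Homo sapiens) for inhibition, read by MTT assay, with a stated time of 24 h (a lower number here means a stronger inhibitor, a higher number a weaker inhibitor), compound 1 gives 42100 nM. For compound 2 the assay reports only a limit, > 150000 nM, so its standing rests on that limit alone (the limit of > 150000 nM in this assay, at which 1 of the 2 values shown sits). The one measured step, an at least 3.5-fold higher number from compound 1 to compound 2 (0.55 log units; beyond the scatter), moves from a weak number to a limit, and compound 2 therefore sits at the weak end of everything shown.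

Compound 3 `CCOC(=O)C1=Cc2ccccc2OC1(OCc1cn(-c2ccc(C)cc2)nn1)C(F)(F)F` differs from compound 2 in one place: methyl in place of nitro on an aromatic carbon. Going by the values given here, no measured step touches this position directly; the step from compound 1 to compound 2 exchanges the whole group on the aromatic nitrogen rather than a substituent on that phenyl ring, so it bears on the question only as a sign of how weak this branch of the series is. With no closer guide, he expects compound 3 to remain near the limit in this assay, with a wide range, and expects the step of an at least 1.2-fold lower number from compound 2 to compound 3 (0.09 log units; that floor lies within the scatter). His estimate for compound 3 is 120000 nM, between 30000 nM and 400000 nM.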

Compound 3, half-maximal inhibitory concentration: 26700 nM
Compound 3: middle estimate off by 4.5-fold (0.65 log units), on the high side; the whole stated range lies above it.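

In this assay, the substituent on the aromatic carbon para to a large group proves to matter, which the earlier step could not show, as it exchanged the whole group on the aromatic nitrogen: methyl in place of nitro gives an at least 5.6-fold lower number from compound 2 to compound 3 (0.74 log units; beyond the scatter). The phenyl ring on the aromatic nitrogen is therefore not weak in itself, for the 4-methylphenyl compound gives a 1.6-fold lower number from compound 1 to compound 3 (0.20 log units; within the scatter), so compound 1 and compound 3 cannot be told apart here even though the 4-methylphenyl and ((2-fluorophenyl)carbamoyl)methyl groups are very different. From the compounds shown here alone, the true size of the nitro-to-methyl step remains unknown, and only its floor can be read, as the value for compound 2 is a limit and not a number: the limit of > 150000 nM in this assay, at which 1 of the 3 values shown sits.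

With a single pair at this position, the compounds shown leave open whether the difference comes from losing the nitro group, from gaining the methyl group, or from both. A phenyl ring with hydrogen at this position, or with an amine, a chlorine atom or a longer chain such as ethyl, would be needed to separate these readings.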